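Swapping bromo for tert-butyl on a hydroxamic acid core

A few compounds are considered here, and "the series" means these few. Any claim that something is new, unique, unknown or untested is made for them only; others in the source may bear on it.

Compound 1 `O=C(CCC1=CCN(Cc2ccc(F)cc2)C1=O)NO` and compound 2 `O=C(CCC1=CCN(Cc2ccc(Br)cc2)C1=O)NO` share a core and differ only in the group on the aromatic carbon. Going by the values given here, in an in vivo ADME assay on the whole organism for pharmacokinetics, with Mus musculus as the target, at a dose of 10 mg/kg by the intravenous route (a higher number here means that more of the compound sits outside the plasma, a lower number that more of the compound stays in the plasma), compound 1 gives 1.8 L/kg, while compound 2 gives 4.1 L/kg, the higher of the two numbers measured so far; the step is a 2.3-fold higher number from compound 1 to compound 2 (0.36 log units; beyond the scatter). Compound 3 `CC(C)(C)c1ccc(CN2CC=C(CCC(=O)NO)C2=O)cc1` is not yet measured. The change that leads to it is tert-butyl in place of bromo on an aromatic carbon. Among the compounds with values here, only one measured step bears on this change, a 2.3-fold higher number from compound 1 to compound 2 (0.36 log units; beyond the scatter), which shows that exchanging one group for another on this aromatic carbon moved the number by a modest amount, beyond the scatter. A further increase in this assay is therefore expected for compound 3, of the size a 1.3-fold higher number from compound 2 to compound 3 (0.13 log units; within the scatter). The estimate for compound 3 in this assay is 5.5 L/kg, with a range from 2.7 L/kg to 11 L/kg.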

Compound 3, volume of distribution at steady state: 1.6 L/kg
The estimate for compound 3 lay 3.4-fold (0.54 log units) above the measured number; measured number below the stated range.
By their numbers in this assay, from the lowest: compounds 3 and 1 (each within the scatter of the next); then compound 2.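

In this assay the groups on this aromatic carbon do not move the number in one direction: tert-butyl in place of bromo gives a 2.6-fold lower number from compound 2 to compound 3 (0.41 log units; beyond the scatter) and so reverses the rise seen from fluoro to bromo, a step beyond the scatter. Tert-butyl in place of fluoro gives a 1.1-fold lower number from compound 1 to compound 3 (0.05 log units; within the scatter) and stays within the scatter, so these two cannot be told apart here, and among the three groups bromo alone stands apart. Nothing measured on these compounds gives a reason for this result.

From the compounds shown here alone, whether chloro or iodo on this carbon would stand with bromo, or with fluoro and tert-butyl, remains open. So does the effect of an amine or a carboxylic acid in this place, and whether the same order would hold on another core.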